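Chlorine position shift in a three-aryl series

The source may hold more compounds than are shown below. What is called first, only, known or untested is meant among the compounds shown, and "the series" means these compounds.

Measured so far:
compound 1 `Oc1ccc(-c2cc(-c3ccc(Cl)cc3)nc(-c3cccs3)c2)cc1`: 6470 nM
compound 2 `Oc1ccc(-c2cc(-c3cccc(Cl)c3)nc(-c3cccs3)c2)cc1`: 5050 nM
compound 3 `Oc1cccc(-c2cc(-c3ccc(Cl)cc3)nc(-c3ccsc3)c2)c1`: 8850 nM

All three numbers come from a functional assay on HCT-15 cells (Homo sapiens) for cytotoxicity, read by CCK-8 assay and cell counting, with a stated time of 2 days; on this read-out higher numbers stand for weaker inhibition and lower numbers for stronger inhibition. The three values sit within the scatter of each other; no order is claimed among compound 1, compound 2 and compound 3.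

One change recurs. From compound 1 to compound 2 it is 3-chlorophenyl in place of 4-chlorophenyl on an aromatic carbon and gives a 1.3-fold lower number from compound 1 to compound 2 (0.11 log units; within the scatter). Compound 4 `Oc1cccc(-c2cc(-c3ccsc3)nc(-c3cccc(Cl)c3)c2)c1`, not yet measured, carries the same kind of change relative to compound 3: 3-chlorophenyl in place of 4-chlorophenyl on an aromatic carbon. The surroundings are not identical: in compound 1 the place is meta to a 4-hydroxyphenyl group and meta to a thiophen-2-yl group, in compound 3 it is meta to a 3-hydroxyphenyl group and meta to a thiophen-3-yl group. How the core of compound 3 differs from the core of compound 1 is not broken down here.

For compound 4 in this assay a step of about a 1.3-fold lower number from compound 3 to compound 4 (0.10 log units; within the scatter) is expected, set beside the earlier one, because the change from compound 1 to compound 2 gave a 1.3-fold lower number from compound 1 to compound 2 (0.11 log units; within the scatter). Compound 4 is therefore estimated at 7000 nM, with a range from 3500 nM to 14000 nM.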

Compound 4, half-maximal inhibitory concentration: 2510 nM
Compound 4: the middle estimate sits 2.8-fold (0.45 log units) above what was measured; measured number outside the range, below it.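

In this assay, 3-chlorophenyl in place of 4-chlorophenyl gives a 3.5-fold lower number from compound 3 to compound 4 (0.55 log units; beyond the scatter) on the core of compound 3, a step beyond the scatter. The change therefore does not carry over from one core to the other with a fixed size: the same change on two cores in this assay, a 1.3-fold lower number (0.11 log units; within the scatter) from compound 1 to compound 2 and a 3.5-fold lower number (0.55 log units; beyond the scatter) from compound 3 to compound 4, 2.8-fold (0.44 log units) apart, beyond the scatter of two such steps. This does not show which feature of the two cores goes with the larger step, and two pairs give no rule for any further core.

Still open, as far as these compounds go, is whether the larger step goes with the 3-hydroxyphenyl group, with the thiophen-3-yl group, or only with the two together, as the core of compound 1 and the core of compound 3 differ in both. Also open, from the compounds shown here alone, is how the series responds when an amine or a carboxylic acid takes the place of the chlorine on either core.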